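Methoxy for chloro on the thiosemicarbazone aryl ring

The source may report more compounds than this note shows. Statements on the series, on what has been measured and on what is new or still open speak of the compounds shown alone.

Measured compounds and their values:
compound 1, `S=C(N/N=C\c1ccnc2ccccc12)Nc1cccnc1`, 91600 nM
compound 2, `S=C(N/N=C\c1ccnc2ccccc12)Nc1ccc(Br)cc1`, 53500 nM
compound 3, `S=C(N/N=C\c1ccnc2ccccc12)Nc1ccc(Cl)cc1`, 63500 nM

All three numbers come from an ADME assay on RAW264.7 cells (Mus musculus) for cytotoxicity, read by MTT assay, with a stated time of 48 h; a lower number here means that less compound is tolerated, a higher number that more compound is tolerated. Compound 3 gives the second highest of the three numbers; its nearest neighbour is compound 2, from which it is separated by a 1.2-fold higher number from compound 2 to compound 3 (0.07 log units; within the scatter), and its furthest is compound 1, separated by a 1.4-fold lower number from compound 1 to compound 3 (0.16 log units; within the scatter). Neither gap is beyond the scatter, so the three compounds cannot be ordered on this assay.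

The unmeasured compound 4, `COc1ccc(NC(=S)N/N=C\c2ccnc3ccccc23)cc1`, is reached from compound 3 by one change: methoxy in place of chloro on an aromatic carbon.

For the measured compounds named here, no measured pair shows methoxy against chloro. Going by the values given here, the steps that bear on it are those that alter the same aryl group: a 1.7-fold lower number from compound 1 to compound 2 (0.23 log units; within the scatter) and a 1.4-fold lower number from compound 1 to compound 3 (0.16 log units; within the scatter), both within the scatter, as is a 1.2-fold higher number from compound 2 to compound 3 (0.07 log units; within the scatter). Every change so far on this part of the shared core has left this assay unmoved beyond the scatter, so compound 4 is expected to behave likewise: the expected step is a 1.1-fold higher number from compound 3 to compound 4 (0.04 log units; within the scatter), in no clear direction. Compound 4 is therefore estimated at 70000 nM, with a range from 35000 nM to 140000 nM.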

Compound 4, half-maximal cytotoxic concentration: 101000 nM
The estimate for compound 4 lay 1.4-fold (0.16 log units) below the measured number; low and high end bracket the measured number.
By their numbers in this assay, from the lowest: compounds 2, 3, 1 and 4 (each within the scatter of the next).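

Read directly for the first time on this aryl ring, methoxy in place of chloro gives a 1.6-fold higher number from compound 3 to compound 4 (0.20 log units; within the scatter) in this assay, and methoxy in place of bromo gives a 1.9-fold higher number from compound 2 to compound 4 (0.28 log units; within the scatter), so both steps stay within the scatter even though methoxy enters with 2 heavy atoms and 1 hydrogen-bond acceptor where chloro had 1 heavy atom and none. The 4-methoxyphenyl group also cannot be told apart from pyridin-3-yl, with a 1.1-fold higher number from compound 1 to compound 4 (0.04 log units; within the scatter), which extends the flat reading to a fourth group on this nitrogen, and every step among the four compounds now lies within the scatter. No accompanying measurement speaks to what lies behind this flat reading.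

Going by these compounds, whether an amine or a carboxylic acid at the same place on the ring, or a longer chain in place of methoxy, would move the number in this assay beyond the scatter remains open. On these data alone, the shared core is the same in all four compounds, so the effect of a change anywhere else on it also remains open.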